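The source may report more compounds than this note shows. Statements on the series, on what has been measured and on what is new or still open speak of the compounds shown alone.

Compound 2 `CNC(=O)[C@@]12C[C@@H]1[C@@H](n1cnc3c(NCc4cccc(Cl)c4)nc(C#CCCCCc4cn(CCNC(C)=O)nn4)nc31)[C@H](O)[C@@H]2O` gives the lowest number of the three measured compounds in an assay on CHO cells for displacement of a labelled ligand from adenosine receptor A3 (Homo sapiens), read by scintillation counting (a higher number here means a weaker inhibitor, a lower number a stronger inhibitor), at 22.3 nM. Compound 3 `C#CCCCCC#Cc1nc(NCc2cccc(Cl)c2)c2ncn([C@H]3[C@H](O)[C@H](O)[C@]4(C(=O)NC)C[C@H]34)c2n1` gives 29.4 nM, and a 1.3-fold higher number from compound 2 to compound 3 (0.12 log units; within the scatter). Compound 1 `CNC(=O)[C@@]12C[C@@H]1[C@@H](n1cnc3c(NCc4cccc(Cl)c4)nc(C#CCCCCc4cn(-c5ccc(C(=O)O)cc5)nn4)nc31)[C@H](O)[C@@H]2O` gives 180 nM, and an 8.1-fold lower number from compound 1 to compound 2 (0.91 log units; beyond the scatter). Compound 4 `CNC(=O)[C@@]12C[C@@H]1[C@@H](n1cnc3c(NCc4cccc(Cl)c4)nc(C#CCCCCc4cn(-c5ccc(N=C=S)cc5)nn4)nc31)[C@H](O)[C@@H]2O` differs from compound 2 by a group of 9 heavy atoms (7 carbon, 1 nitrogen, 1 sulfur; one six-membered aromatic ring of carbon only) in place of a group of 6 heavy atoms (4 carbon, 1 nitrogen, 1 oxygen; no ring), on an aromatic nitrogen. Going by the values given here, the step from compound 1 to compound 2 bears on this change, since both compound 1 and compound 4 carry a six-membered aromatic ring on that nitrogen while compound 2 carries a chain; that step was large, so a higher number is expected for compound 4, though the ring it carries is not the one in compound 1. Compound 4 is therefore estimated at 60 nM, within 20 nM to 200 nM, meaning an expected 2.7-fold higher number from compound 2 to compound 4 (0.43 log units; beyond the scatter).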

Compound 4, inhibition constant: 37.5 nM
Compound 4: middle estimate off by 1.6-fold (0.20 log units), on the high side; the range from low to high includes it.
By their numbers in this assay, from the lowest: compounds 2, 3 and 4 (each within the scatter of the next); then compound 1.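

In this assay there is a 1.7-fold higher number from compound 2 to compound 4 (0.23 log units; within the scatter) when a six-membered aromatic ring of carbon only replaces 2-acetamidoethyl on the aromatic nitrogen, so such a ring there does not by itself carry the loss seen with compound 1. With the ring kept, isothiocyanate in place of carboxylic acid on the aromatic carbon gives a 4.8-fold lower number from compound 1 to compound 4 (0.68 log units; beyond the scatter) and places that gap in the group on the ring. The data shown offer no evidence on the reason for this. As far as these compounds go, whether an amine or a methyl ester on that ring would side with compound 4 or with compound 1 stays open.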